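Swapping a para-ethyl for a meta-methyl on the pendant ring

A few compounds are considered here, and "the series" means these few. Any claim that something is new, unique, unknown or untested is made for them only; others in the source may bear on it.

The measured compounds so far:
- Compound 1, `Clc1ccc(-c2cn3ccnc3c(-c3ccc4ncn(C5CCCCC5)c4c3)n2)cc1`: in a functional assay on RXF 393 cells (Homo sapiens) for inhibition, read by sulforhodamine B assay, with a stated time of 48 h, tested at 10 uM (a lower number here means less inhibition, a higher number more inhibition at the concentration tested (going by the name of the read-out)), compound 1 gives 6.73%.
- Compound 2, `Brc1ccc(-c2cn3ccnc3c(-c3ccc4ncn(C5CCCCC5)c4c3)n2)cc1`: compound 2 gives 34%.
- Compound 3, `CCc1ccc(-c2cn3ccnc3c(-c3ccc4ncn(Cc5ccccc5)c4c3)n2)cc1`: compound 3 gives 30.7%.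

All three share one core and differ only in the group hanging from it and the substituent on the pendant ring. Within the data shown here, the single measured step between neighbours is a number 27.3 percentage points higher from compound 1 to compound 2 (beyond the scatter). Compound 3 stands second highest of the three; its number sits within the scatter of compound 2 and beyond the scatter above compound 1.

Compound 4, `Cc1cccc(-c2cn3ccnc3c(-c3ccc4ncn(Cc5ccccc5)c4c3)n2)c1`, differs from compound 3 by 3-methylphenyl in place of 4-ethylphenyl on an aromatic carbon. Among the measured compounds shown here, no measured step exchanges one alkyl-bearing ring for another, so the only available step, from chloro to bromo, does not bear on this change. With nothing in the data pointing either way, the estimate for compound 4 is a step of a number 2.7 percentage points lower from compound 3 to compound 4 (within the scatter), that is, none beyond the scatter, giving an expected 28% within a range from 10% to 48%.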

Compound 4, a percentage reported as inhibition, at one concentration (the size of the read-out at that concentration, not a potency): 2.01%
Estimate against measurement, compound 4: 26 percentage points above; measured number below the stated range.
By their numbers in this assay, from the lowest: compounds 4 and 1 (each within the scatter of the next); then compounds 3 and 2 (each within the scatter of the next).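

In this assay, the pendant ring on the shared core proves sensitive to its alkyl group: 3-methylphenyl in place of 4-ethylphenyl gives a number 28.7 percentage points lower from compound 3 to compound 4 (beyond the scatter). Among these compounds, the earlier step involved only two halogens on a core with a different attached group, whereas this one shows that a change between alkyl-bearing rings can also move the number beyond the scatter. The swap alters the group's place on the ring and its size together, and no measurement available here explains the step.

The compounds shown cannot separate place from size, which would take 4-methylphenyl or 3-ethylphenyl on the core of compound 3. Also open, going by these compounds, is how a pendant ring carrying an amine or a carboxylic acid would behave in this assay.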